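The source may report more compounds than this note shows. Statements on the series, on what has been measured and on what is new or still open speak of the compounds shown alone.

In an ADME assay on microsomes from liver (Homo sapiens) for metabolic stability (on this read-out higher numbers stand for fast clearance and lower numbers for slow clearance), compound 1 (`CC1(C)CN(c2ccc3c(n2)NC(=O)CO3)[C@H](c2ccccc2)CO1`) gives 15.2 mL.min-1.g-1 and compound 2 (`N#CC[C@@H]1CN(c2ccc3c(n2)NC(=O)CO3)[C@H](c2ccccc2)CO1`) gives 11.9 mL.min-1.g-1, so the two numbers lie within the scatter of each other. Compound 3 (`COC[C@@H]1CN(c2ccc3c(n2)NC(=O)CO3)[C@H](c2ccccc2)CO1`) differs from compound 2 in one place: methoxy in place of cyano on a saturated chain carbon bound to a saturated ring carbon. This puts methoxy in place of cyano on a saturated chain carbon bound to a saturated ring carbon. For the measured compounds named here, no measured pair shows this change, so only a small rise in this assay, within the scatter, is expected. The estimated move is a 1.4-fold higher number from compound 2 to compound 3 (0.15 log units; within the scatter). For compound 3 the expected value is 17 mL.min-1.g-1, with an estimated range of 9 mL.min-1.g-1 to 32 mL.min-1.g-1.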

Compound 3, intrinsic clearance in microsomes in the liver assay: 8 mL.min-1.g-1
The estimate for compound 3 lay 2.1-fold (0.33 log units) above the measured number; measured number outside the range, below it.
By their numbers in the liver assay, from the lowest: compounds 3, 2 and 1 (each within the scatter of the next).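

In the liver assay the change from cyano to methoxy on a saturated chain carbon bound to a saturated ring carbon gives a 1.5-fold lower number from compound 2 to compound 3 (0.17 log units; within the scatter) and thus no step beyond the scatter at this position, with compound 2 at 11.9 mL.min-1.g-1 and compound 3 at 8 mL.min-1.g-1. In a physicochemical assay for lipophilicity (a higher number here means a more lipophilic compound, a lower number a more polar compound), the same change gives a number 0.20 log units higher from compound 2 to compound 3 (within the scatter) and so also stays inside the scatter, with compound 2 at 2.3 and compound 3 at 2.5, which means that neither read-out separates these two groups here.

On these data alone, whether an amine or a carboxylic acid at this place would also stay within the scatter remains open. Nothing available accounts for these results.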